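The source may hold more compounds than are shown below. What is called first, only, known or untested is meant among the compounds shown, and "the series" means these compounds.

Measured so far in a functional assay on 3T3-L1 cells (Mus musculus) for inhibition, with a stated time of 20 min, tested at 20 uM; on this read-out higher numbers stand for more inhibition at the one concentration tested (going by the name of the read-out) and lower numbers for less inhibition:
- compound 1, `COc1cc(OC)c(Cn2cc(CN(Cc3cn(S(=O)(=O)c4ccc(C)cc4)c4ccccc34)S(=O)(=O)c3ccc(C)cc3)nn2)c(OC)c1`: -22%
- compound 2, `CC(=O)N(Cc1cn(Cc2cccc(F)c2F)nn1)Cc1cn(S(=O)(=O)c2ccc(C)cc2)c2ccccc12`: 39.5%
- compound 3, `COc1ccc(Cn2cc(CN(Cc3cn(S(=O)(=O)c4ccc(C)cc4)c4ccccc34)S(=O)(=O)c3ccc(C)cc3)nn2)c(OC)c1OC`: -18%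

Compound 3 sits second highest of the three numbers. Its nearest neighbour is compound 1, whose reading is within the scatter of that of compound 3 (a number 4 percentage points higher from compound 1 to compound 3 (within the scatter)). The furthest is compound 2, which lies well beyond the scatter above compound 3; compound 2 differs from compound 3 in two places at once, so nothing in that gap can be assigned to either change alone.

Compound 4, `Cc1ccc(S(=O)(=O)N(Cc2cn(Cc3cccc(F)c3F)nn2)Cc2cn(S(=O)(=O)c3ccc(C)cc3)c3ccccc23)cc1`, is not yet measured. Against compound 3 the change is 2,3-difluorophenyl in place of 2,3,4-trimethoxyphenyl on a saturated chain carbon bound to an aromatic nitrogen.

Within the data shown here, the only measured step at the same place is the swap of one trimethoxyphenyl pattern for another, which gave a number 4 percentage points higher from compound 1 to compound 3 (within the scatter). Among the measured compounds shown here, no measured step isolates the move from a trimethoxyphenyl to a difluorophenyl ring with the rest of the molecule held fixed. For compound 4 in this assay a step of a number 18 percentage points higher from compound 3 to compound 4 (beyond the scatter) from compound 3 is therefore expected, modest and uncertain in direction. The estimate for compound 4 is 0%, with a range from -25% to 30%.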

Compound 4, a percentage reported as inhibition, at one concentration (the size of the read-out at that concentration, not a potency): 71.5%
Compound 4: the middle estimate sits 71.5 percentage points below what was measured; measured number outside the range, above it.
By their numbers in this assay, from the lowest: compounds 1 and 3 (each within the scatter of the next); then compound 2; then compound 4.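

In this assay, the saturated chain carbon bound to an aromatic nitrogen proves highly sensitive to the ring it carries: 2,3-difluorophenyl gives a number 89.5 percentage points higher from compound 3 to compound 4 (beyond the scatter) in place of 2,3,4-trimethoxyphenyl and a number 93.5 percentage points higher from compound 1 to compound 4 (beyond the scatter) in place of 2,4,6-trimethoxyphenyl, whereas exchanging one trimethoxyphenyl pattern for the other stayed within the scatter. The amine nitrogen also responds with the 2,3-difluorophenyl ring held fixed, as (4-methylphenyl)sulfonyl in place of acetyl gives a number 32 percentage points higher from compound 2 to compound 4 (beyond the scatter) and leaves compound 4 highest of the four. No available evidence accounts for either step.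

From the compounds shown here alone, it remains open whether the gain follows the two fluorines or the loss of the methoxy groups, which a plain phenyl or 2,3-dichlorophenyl ring would help separate. Also open, going by these compounds, is how an amine or a carboxylic acid on that ring would read.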